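A Bromine Moved Around the Ring of Compound 1

The compounds below may be only part of what the source reports. "The series", "measured", "known", "first", "only" and "open" are said of these compounds alone.

Compound 1 `COc1cc2c(cc1OC)C(=O)C(C(=O)Nc1ccc(Br)cc1)C2`: 3.03
Compound 2 `COc1cccc(NC(=O)C2Cc3cc(OC)c(OC)cc3C2=O)c1`: 2.08
Compound 3 `COc1cc2c(cc1OC)C(=O)C(C(=O)Nc1cccc(Cl)c1)C2`: 2.76

These three compounds share one core and differ only in the ring carried on the amide-type nitrogen. In a physicochemical assay for lipophilicity, read by mass spectrometry (a lower number here means a more polar compound, a higher number a more lipophilic compound), compound 1 stands highest of the three; compound 3 is nearest to it and compound 2 furthest. The step of a number 0.95 log units lower from compound 1 to compound 2 (beyond the scatter) lies beyond the scatter, whereas a number 0.27 log units lower from compound 1 to compound 3 (within the scatter) stays within it. Between the two smaller compounds, a number 0.68 log units higher from compound 2 to compound 3 (beyond the scatter).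

Compound 4 `COc1cc2c(cc1OC)C(=O)C(C(=O)Nc1ccccc1Br)C2` holds exactly the same atoms as compound 1, joined differently: 2-bromophenyl in place of 4-bromophenyl on an amide-type nitrogen. Within the data shown here, no measured step moves a bromine from one place on the ring to another. Among the measured compounds shown here, the only step that exchanges one halogen-bearing ring for another, from compound 1 to compound 3, is within the scatter, and the one clearly larger step involves a methoxy-bearing ring. The expectation is therefore a small step at most: a number 0.13 log units lower from compound 1 to compound 4 (within the scatter) is expected. Compound 4 is estimated at 2.9, with a range from 2.5 to 3.3.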

Compound 4, partition coefficient: 3.03
Beside the measured number, compound 4's estimate is 0.13 log units below it; low and high end bracket the measured number.
By their numbers in this assay, from the lowest: compound 2; then compounds 3, 1 and 4 (each within the scatter of the next).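

Moving the bromine, with 2-bromophenyl in place of 4-bromophenyl on the amide-type nitrogen, gives the first pair here with identical atoms, and in this assay it reads (  no change at the digits printed from compound 1 to compound 4 (within the scatter)  ), so for these two compounds the place of the bromine on the ring does not show in the number. The new compound also stays close to the chloro-bearing compound (a number 0.27 log units higher from compound 3 to compound 4 (within the scatter)), while the methoxy-bearing compound remains clearly apart (a number 0.95 log units higher from compound 2 to compound 4 (beyond the scatter)). Nothing available explains why the two bromine placements read alike.

Going by these compounds, whether a methoxy group or a chlorine would behave the same way when moved around the ring stays open. So does what a ring carrying an amine or a carboxylic acid in place of the bromine would read.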